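A few compounds are considered here, and "the series" means these few. Any claim that something is new, unique, unknown or untested is made for them only; others in the source may bear on it.

Compound 1 `O=C(CSc1nc2c(c(=O)n1-c1ccccc1)SCC2)Nc1nc2ccc(Cl)cc2s1` gives 40 nM in an assay on L cells for inhibition of Protein-serine O-palmitoleoyltransferase porcupine (Mus musculus), read by reporter gene assay, with a stated time of 24 h; on this read-out higher numbers stand for an effect only at larger amounts of compound and lower numbers for an effect already at smaller amounts. Compound 2 `CCOc1ccc(NC(=O)CSc2nc3c(c(=O)n2-c2ccccc2)SCC3)cc1` gives 1000 nM in this assay. Compound 3 `CN(C)c1ccc(NC(=O)CSc2nc3c(c(=O)n2-c2ccccc2)SCC3)cc1` reaches only the limit of the assay, > 1000 nM, in this assay.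

Among these, compound 1 holds the lowest of the two numbers; its nearest neighbour is compound 2, reached by a 25-fold higher number from compound 1 to compound 2 (1.40 log units; beyond the scatter) when 4-ethoxyphenyl replaces 6-chloro-1,3-benzothiazol-2-yl on the amide-type nitrogen. Compound 3 likewise shows an at least 25-fold higher number from compound 1 to compound 3 (1.39 log units; beyond the scatter) for 4-(dimethylamino)phenyl in place of the same benzothiazolyl group. Between compound 2 and compound 3 the change of dimethylamino for ethoxy on an aromatic carbon gives a number no lower from compound 2 to compound 3 (the limit leaves the size open), its size hidden by the limit of > 1000 nM in this assay, at which 1 of the 3 values shown sits.

Compound 4 `O=C(CSc1nc2c(c(=O)n1-c1ccccc1)SCC2)Nc1nc2ccc(C(F)(F)F)cc2s1` keeps the benzothiazolyl amide of compound 1 and differs only by trifluoromethyl in place of chloro on an aromatic carbon. No measured step exchanges one small substituent on that fused ring; the two large steps concern the replacement of the whole ring, and the one substituent swap shown carries no readable size. For compound 4 the step is therefore expected to stay within the scatter, a 1.3-fold higher number from compound 1 to compound 4 (0.10 log units; within the scatter), and compound 4 is estimated at 50 nM in this assay, between 15 nM and 160 nM.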

Compound 4, half-maximal effective concentration: 40 nM
Compound 4: the middle estimate sits 1.3-fold (0.10 log units) above what was measured; measured number inside the range.
By their numbers in this assay, from the lowest: compounds 1 and 4 (each within the scatter of the next); then compound 2.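

Earlier steps replaced the whole benzothiazolyl group, whereas this one exchanges only the substituent on the six-membered aromatic ring of the fused system, and in this assay it gives no change at the digits printed from compound 1 to compound 4 (within the scatter). This aromatic carbon therefore accepts trifluoromethyl, which carries more heavy atoms than chloro, without a readable shift on this read-out, so the large steps seen earlier are not matched by this exchange on the retained ring. Nothing shown here accounts for this lack of change.

The compounds shown leave open how this carbon responds to groups other than these two, such as an amine, a carboxylic acid, a methoxy group or a longer alkyl chain, and whether the unsubstituted ring would read the same. They also leave open whether substituents on the phenyl amides can be ranked, since the step from compound 2 to compound 3 cannot be read, compound 3 being at a limit of the assay: the limit of > 1000 nM in this assay, at which 1 of the 4 values shown sits.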